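A Selenium-Bearing Chain on the Same Weak Lead

The compounds below may be only part of what the source reports. "The series", "measured", "known", "first", "only" and "open" are said of these compounds alone.

Compound 1 `COc1ccc(N(C)c2ccnc(Cl)n2)cc1` gives the lowest number of the three compounds measured in a functional assay on HeLa cells (Homo sapiens) for antiproliferative activity, read by MTT assay, with a stated time of 48 h (on this read-out lower numbers stand for stronger inhibition and higher numbers for weaker inhibition), namely 917 nM. Compound 2 `COc1ccc(N(C)c2ccnc(Cl)n2)cc1OCCBr` reaches 3310 nM and compound 3 `COc1ccc(N(C)c2ccnc(Cl)n2)cc1OCCCCCBr` reaches 7090 nM; both chains attached to the core raised the number, with a 3.6-fold higher number from compound 1 to compound 2 (0.56 log units; beyond the scatter) and a 7.7-fold higher number from compound 1 to compound 3 (0.89 log units; beyond the scatter). Compound 4 `COc1ccc(N(C)c2ccnc(Cl)n2)cc1OCC[Se]C#N` changes compound 1 at the same place: a group of 6 heavy atoms (3 carbon, 1 nitrogen, 1 oxygen, 1 selenium; no ring) in place of a hydrogen atom, on an aromatic carbon. The step from compound 1 to compound 2 bears most on this, as it also adds a short chain there, while the step to compound 3 shows that a longer chain weakens further. A modest rise is therefore expected for compound 4, a 2.8-fold higher number from compound 1 to compound 4 (0.45 log units; beyond the scatter). The estimate for compound 4 is 2600 nM, within a range from 900 nM to 7500 nM.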

Compound 4, half-maximal inhibitory concentration: 436 nM
Compound 4: middle estimate off by 6.0-fold (0.78 log units), on the high side; measured number outside the range, below it.
By their numbers in this assay, from the lowest: compound 4; then compound 1; then compound 2; then compound 3.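

In this assay, this position can carry a chain and still give a lower number than the unsubstituted compound (a 2.1-fold lower number from compound 1 to compound 4 (0.32 log units; beyond the scatter)), which neither bromo chain did. What ends the chain therefore matters, as the selenium-bearing end gives large gains over the bromo chains (a 7.6-fold lower number from compound 2 to compound 4 (0.88 log units; beyond the scatter); a 16-fold lower number from compound 3 to compound 4 (1.21 log units; beyond the scatter)), though the latter step also changes chain length. Nothing available explains this difference.

The compounds shown do not separate the part played by the selenium from that of the nitrile. Going by these compounds, what a sulfur atom in place of selenium, or a longer chain with the same end, would do remains open.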